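Adding a (Dimethylamino)methyl Tail: Expected Cytotoxicity of Compound 4

The source may hold more compounds than are shown below. What is called first, only, known or untested is meant among the compounds shown, and "the series" means these compounds.

Measured so far:
compound 1 `COc1ccc(NC(=O)c2ccc(OCCCN(C)C)c([N+](=O)[O-])c2)cc1` gives 127000 nM
compound 2 `CCC(=O)Nc1cc(C(=O)Nc2ccc(OC)cc2)ccc1OC` gives 109000 nM
compound 3 `CCOc1ccc(C(=O)Nc2ccc(OC)cc2)cc1NC(=O)CC` gives 73200 nM

These three numbers all come from a toxicity assay on Huh-7.5 cells (Homo sapiens) for inhibition, read by MTT assay, with a stated time of 96 h; a lower number here means that less compound is tolerated, a higher number that more compound is tolerated. Compound 3 sits at the lower end of the three, but its gaps to compound 2 and to compound 1 are both within the scatter, so the three cannot be told apart on these data.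

The next compound, compound 4 `CCC(=O)Nc1cc(C(=O)Nc2ccc(OC)cc2)ccc1OCCCN(C)C`, has not yet been measured. It differs from compound 3 by (dimethylamino)methyl in place of hydrogen on a saturated chain carbon, two bonds along the chain from an oxygen on an aromatic ring.

Among the measured compounds shown here, only one measured step involves a single change, a 1.5-fold lower number from compound 2 to compound 3 (0.17 log units; within the scatter), and it did not move the number beyond the scatter. For the measured compounds named here, no measured pair isolates the present change; compound 4 carries the same 3-(dimethylamino)propoxy group as compound 1, and compound 1 gives 127000 nM, a number within the scatter of compound 3. On this basis compound 4 is expected to stay close to compound 3, with a 1.2-fold higher number from compound 3 to compound 4 (0.09 log units; within the scatter) as the estimated step. The estimate for compound 4 in this assay is 90000 nM, in the range 40000 nM to 200000 nM.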

Compound 4, half-maximal cytotoxic concentration: 154000 nM
Estimate against measurement, compound 4: 1.7-fold (0.23 log units) below, and the stated range covers the measured number.
By their numbers in this assay, from the lowest: compounds 3, 2, 1 and 4 (each within the scatter of the next, the first and the last beyond it).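

Among the compounds shown here, measured in this assay, extending the ethoxy group to 3-(dimethylamino)propoxy gives a 2.1-fold higher number from compound 3 to compound 4 (0.32 log units; beyond the scatter), the first single change here to pass the scatter, so this position tolerates a sizeable tail without any fall in the number. The gain is small and depends on the reference point, since swapping methoxy for the same tail gives a 1.4-fold higher number from compound 2 to compound 4 (0.15 log units; within the scatter), and propanoylamino in place of nitro on the aromatic carbon gives a 1.2-fold higher number from compound 1 to compound 4 (0.08 log units; within the scatter), both too small to separate the compounds. Nothing on hand explains these steps.

On these data alone, it remains open whether the dimethylamino end matters or the chain alone is enough, which a plain propoxy group would test. A morpholine or a carboxylic acid at the chain end, or a longer chain, could also show how far the tail can change here.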